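Replacement of the lactam-bearing aryl on the ring nitrogen in compound 2

A few compounds are considered here, and "the series" means these few. Any claim that something is new, unique, unknown or untested is made for them only; others in the source may bear on it.

Three compounds of this series have numbers in a functional assay on SGC-7901 cells (Homo sapiens) for inhibition, read by MTT assay, with a stated time of 72 h; a higher number here means a weaker inhibitor of growth, a lower number a stronger inhibitor of growth. Compound 1 `CC1=C(CCCCCCCCCCn2cc(C[C@H](O)COCCOC[C@@H](O)Cc3ccc(-c4ccccc4)cc3)nn2)C(=O)c2ccccc2C1=O` gives 390 nM and is the lowest number among the three. Compound 3 `COC1=C(OC)C(=O)C(CCCCCCCCCCCCCCCn2cc(C[C@H](O)COCCOC[C@@H](O)Cc3ccc(-c4ccccc4)cc3)nn2)=C(C)C1=O` gives 2490 nM. Compound 2 `O=C1COc2ccc(-n3cc(C[C@H](O)COCCOC[C@@H](O)Cc4ccc(-c5ccccc5)cc4)nn3)cc2N1` gives 15200 nM, the highest of the three numbers; the nearest to it, compound 3, lies beyond the scatter, and the furthest, compound 1, lies well beyond it. Among the measured compounds shown here, compounds 1 and 3 both carry a quinone-type ring through a long chain, while compound 2 has its aryl group directly on the aromatic nitrogen, so no single-point step between measured compounds exists here.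

Compound 4 `O[C@H](COCCOC[C@@H](O)Cc1cn(-c2cncc3ccccc23)nn1)Cc1ccc(-c2ccccc2)cc1` has not yet been measured. It differs from compound 2 at one place: a group of 10 heavy atoms (9 carbon, 1 nitrogen; one six-membered aromatic ring of carbon only, one six-membered aromatic ring with 1 hetero atom) in place of a group of 11 heavy atoms (8 carbon, 1 nitrogen, 2 oxygen; one six-membered non-aromatic ring with 2 hetero atoms, one six-membered aromatic ring of carbon only), on an aromatic nitrogen. The group that leaves carries 1 hydrogen-bond donor and 2 hydrogen-bond acceptors; isoquinolin-4-yl, which enters, carries none and 1.

For the measured compounds named here, with no measured step of this kind, only a modest downward move is expected, a 1.9-fold lower number from compound 2 to compound 4 (0.28 log units; within the scatter), close to the scatter. Compound 4 is therefore estimated at 8000 nM, within a range from 2500 nM to 25000 nM.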

Compound 4, concentration for 50% growth inhibition: 29300 nM
Beside the measured number, compound 4's estimate is 3.7-fold (0.56 log units) below it; measured number outside the range, above it.
By their numbers in this assay, from the lowest: compound 1; then compound 3; then compounds 2 and 4 (each within the scatter of the next).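

In this assay, isoquinolin-4-yl on the aromatic nitrogen of the five-membered ring, in place of the lactam-bearing aryl group, gives a 1.9-fold higher number from compound 2 to compound 4 (0.29 log units; within the scatter). Among the compounds shown here, this is the first single-place reading at this position, and it shows that an exchange of two-ring groups differing in their hetero atoms and in ring type, with 1 hydrogen-bond donor and 2 hydrogen-bond acceptors leaving and 0 hydrogen-bond donors and 1 hydrogen-bond acceptor entering, is not resolved from the scatter of this read-out. For the compounds shown here, no measurement on these compounds gives a basis for interpreting the step.

Still open, on these data alone, is whether a plain phenyl, or an aryl group carrying an amine or a carboxylic acid, on this nitrogen would separate from compound 2 beyond the scatter. Also open, as far as these compounds go, is what the long chains and quinone-type rings of compound 1 and compound 3 contribute on their own, as these compounds differ from compound 2 and compound 4 in more than one place and their comparisons cannot be read as steps.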